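This account rests on a few compounds, and the source may have more. Where it says the series, first, only, none or still open, it means among the compounds named here.

In an ADME assay on ECV-304 cells (Homo sapiens) for cytotoxicity, read by MTT assay, with a stated time of 72 h (on this read-out higher numbers stand for weaker inhibition and lower numbers for stronger inhibition), compound 2 `COc1ccc(C2=C(c3cc(OC)c(OC)c(OC)c3)C(=O)C(OC(C)=O)C2)cc1F` gives 41 ug/mL, the higher of the two true numbers in this small set. Compound 1 `COc1ccc(C2=C(c3cc(OC)c(OC)c(OC)c3)C(=O)C(OC(C)=O)C2)cc1OC(C)C` reads > 100 ug/mL, which is a limit of the assay. Compound 3 `COc1ccc(C2=C(c3cc(OC)c(OC)c(OC)c3)C(=O)C(O)C2)cc1F` gives 19.5 ug/mL. Hydrogen in place of acetyl on an oxygen on a saturated carbon accounts for a 2.1-fold lower number from compound 2 to compound 3 (0.32 log units; beyond the scatter), but that change lies elsewhere in the molecule. Compound 4 `COc1ccc(C2=C(c3cc(OC)c(OC)c(OC)c3)C(=O)C(OC(C)=O)C2)cc1Cl` carries chloro in place of fluoro on an aromatic carbon. Among the compounds with values here, the only measured step at this aromatic carbon, an at least 2.4-fold lower number from compound 1 to compound 2 (0.38 log units; beyond the scatter), replaced isopropoxy with fluoro, so it gives no firm direction for chloro. The expected change is a 1.1-fold higher number from compound 2 to compound 4 (0.04 log units; within the scatter), with no step beyond the scatter anticipated. For compound 4 the estimated value is 45 ug/mL, within a range of 20 ug/mL to 100 ug/mL.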

Compound 4, half-maximal inhibitory concentration: 3.5 ug/mL
For compound 4 the middle estimate is 13-fold (1.11 log units) above the measured one; the measured number lies below the stated range.
By their numbers in this assay, from the lowest: compound 4; then compound 3; then compound 2. At a limit, above all of these: compound 1.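

In this assay, within the data shown here, this aromatic carbon proves far more sensitive than the earlier compounds showed, for even an exchange of one halogen for another, chloro in place of fluoro, gives a 12-fold lower number from compound 2 to compound 4 (1.07 log units; beyond the scatter). Chloro in place of isopropoxy gives an at least 28-fold lower number from compound 1 to compound 4 (1.45 log units; beyond the scatter), a larger gap than the fluoro compound showed against the same partner. Compound 1 stands at a limit, so this step is only a bound: the limit of > 100 ug/mL in this assay, at which 1 of the 4 values shown sits.

As far as these compounds go, whether bromo, methyl or an amine at this carbon would follow chloro or fluoro remains open. So does whether hydrogen in place of acetyl on the oxygen would lower the number with chloro present, as it does with fluoro.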